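This account rests on a few compounds, and the source may have more. Where it says the series, first, only, none or still open, it means among the compounds named here.

Measured in a functional assay on MIA PaCa-2 cells (Homo sapiens) for inhibition, read by MTT assay, with a stated time of 7 days; on this read-out higher numbers stand for weaker inhibition and lower numbers for stronger inhibition:
compound 1 `CCN(CC)S(=O)(=O)c1ccc(S(=O)(=O)N2CCC[C@@H](C(=O)NC3COC3)C2)cc1`: 2340 nM
compound 2 `CCN(CC)S(=O)(=O)c1ccc(S(=O)(=O)N2CCC[C@@H](C(=O)N[C@@H]3CCOC3)C2)cc1`: 750 nM
compound 3 `CCN(CC)S(=O)(=O)c1ccc(S(=O)(=O)N2CCC[C@@H](C(=O)N3CC[C@H](OC)C3)C2)cc1`: 2460 nM

Compound 3 gives the highest of the three numbers in this assay; its gap to compound 1 is within the scatter, a 1.1-fold higher number from compound 1 to compound 3 (0.02 log units; within the scatter), while against compound 2 the step is a 3.3-fold higher number from compound 2 to compound 3 (0.52 log units; beyond the scatter). Compound 4 `CCN(CC)S(=O)(=O)c1ccc(S(=O)(=O)N2CCC[C@@H](C(=O)N3CCC(C(F)F)CC3)C2)cc1` differs from compound 3 by 4-(difluoromethyl)piperidin-1-yl in place of 3-methoxypyrrolidin-1-yl on a carbonyl carbon. Going by the values given here, the two measured steps that reach compound 3 both alter the group on the carbonyl carbon, but neither exchanges one tertiary amide ring for another, so no step covers this change directly. A ring-for-ring swap of this kind is expected to sit close to the scatter, with no firm direction: the expected step is a 1.0-fold higher number from compound 3 to compound 4 (0.01 log units; within the scatter). Compound 4 is therefore estimated at 2500 nM, between 900 nM and 7000 nM.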

Compound 4, half-maximal inhibitory concentration: 420 nM
Compound 4: middle estimate off by 6.0-fold (0.77 log units), on the high side, and the stated range ends above it.
By their numbers in this assay, from the lowest: compounds 4 and 2 (each within the scatter of the next); then compounds 1 and 3 (each within the scatter of the next).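

At this carbonyl carbon, a tertiary amide can give a clearly lower number in this assay: 4-(difluoromethyl)piperidin-1-yl separates from 3-methoxypyrrolidin-1-yl (a 5.9-fold lower number from compound 3 to compound 4 (0.77 log units; beyond the scatter)) and from (oxetan-3-yl)amino (a 5.6-fold lower number from compound 1 to compound 4 (0.75 log units; beyond the scatter)). Against (oxolan-3-yl)amino the exchange stays within the scatter (a 1.8-fold lower number from compound 2 to compound 4 (0.25 log units; within the scatter)), so the ring amide matches the better secondary amide rather than passing it. No supporting data bear on why this exchange lowers the number.

The ring size and the difluoromethyl group changed together, so their shares stay unseparated. Plain piperidin-1-yl and 3-(difluoromethyl)pyrrolidin-1-yl would divide them.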